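The source may hold more compounds than are shown below. What is called first, only, known or untested is meant among the compounds shown, and "the series" means these compounds.

Two compounds have been measured in an ADME assay on HepG2 2.2.15 cells (Homo sapiens) for cytotoxicity; on this read-out lower numbers stand for higher toxicity in this test and higher numbers for lower toxicity in this test:

compound 1 `COc1nc2ccc(Cl)cc2c(-c2ccccc2Cl)c1CCO`: 141000 nM
compound 2 `CC(C)(C)[Si](CCc1c(OCc2c(F)cccc2F)nc2ccc(Cl)cc2c1-c1ccccc1Cl)(c1ccccc1)c1ccccc1`: > 1860000 nM

In this assay compound 1 gives 141000 nM. For compound 2 the result is only a limit, > 1860000 nM, and no exact value is known. This is the limit of > 1860000 nM in this assay, at which 1 of the 2 values shown sits. Compound 3 `CC(C)(C)[Si](CCc1c(OS(=O)(=O)C(F)(F)F)nc2ccc(Cl)cc2c1-c1ccccc1Cl)(c1ccccc1)c1ccccc1` has not yet been measured in this assay. It differs from compound 2 in one place: (trifluoromethyl)sulfonyl in place of 2,6-difluorobenzyl on an oxygen on an aromatic ring. Among the compounds with values here, no step between measured compounds covers this change, and the limit on compound 2 gives no precise starting point. The step from compound 2 to compound 3 is expected to be an at least 1.8-fold lower number from compound 2 to compound 3 (0.26 log units; that floor lies within the scatter), that is, no change beyond the usual scatter in either direction. Compound 3 is therefore estimated at 1000000 nM, with a range from 200000 nM to 3000000 nM, and a result given again only as a limit is quite possible.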

Compound 3, half-maximal cytotoxic concentration: > 1560000 nM
Compound 3 was reported as a limit; the forecaster's own chance of this, stated with the estimate: 50%; at least 1.5-fold (0.19 log units) between middle value and limit.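

Like compound 2, compound 3 gives only a limit in this assay (> 1560000 nM), so no step from compound 2 to compound 3 can be read. The compounds shown leave open whether (trifluoromethyl)sulfonyl in place of 2,6-difluorobenzyl changes this read-out at all, and by how much.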